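This account rests on a few compounds, and the source may have more. Where it says the series, first, only, none or still open, it means among the compounds named here.

Compound 1 `Cc1c(OCc2cccc(-c3cccc(C(=O)O)c3)c2)cc2c(c1C)C(=O)C(C1CCCC1)C2` — in an assay on HEK293 cells for positive allosteric modulation of metabotropic glutamate receptor 2 (Rattus norvegicus), read by thallium flux (a lower number here means a smaller maximal response, a higher number a larger maximal response), compound 1 gives 118%.
Compound 2 `Cc1c(OCc2cccc(-c3ccc(O)c(C(=O)O)c3)c2)cc2c(c1C)C(=O)C(C1CCCC1)C2` — in this assay compound 2 gives 113%.

Among the measured compounds shown here, compound 2 stands on one of only two numbers so far; its single neighbour is compound 1, and the step of a number 5 percentage points lower from compound 1 to compound 2 (within the scatter) lies within the scatter, so the two compounds cannot be told apart on this read-out.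

Compound 3 `COc1ccc(-c2cccc(COc3cc4c(c(C)c3C)C(=O)C(C3CCCC3)C4)c2)cc1C(=O)O` has not yet been measured. It differs from compound 2 in one place: methyl in place of hydrogen on an oxygen on an aromatic ring. For the measured compounds named here, no measured step touches this oxygen; the only step in hand, a number 5 percentage points lower from compound 1 to compound 2 (within the scatter), concerns the hydroxy itself and stayed within the scatter. With no change in hand that moved the maximal response beyond the scatter, a step of no size beyond the scatter is expected for compound 3, that is no change at the digits printed from compound 2 to compound 3 (within the scatter). Compound 3 is therefore estimated at 113% in this assay, within a range from 98% to 128%.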

Compound 3, largest response reached (Emax), in percent of the reference or control that the assay uses: 81%
Beside the measured number, compound 3's estimate is 32 percentage points above it, and the stated range ends above it.
By their numbers in this assay, from the lowest: compound 3; then compounds 2 and 1 (each within the scatter of the next).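

In this assay, methyl on the oxygen on the aromatic ring is the first change among these compounds to pass the scatter, giving a number 32 percentage points lower from compound 2 to compound 3 (beyond the scatter). The aromatic carbon that carries this oxygen is therefore not indifferent to what is placed on it: hydroxy in place of hydrogen gave a number 5 percentage points lower from compound 1 to compound 2 (within the scatter), whereas methoxy gave a number 37 percentage points lower from compound 1 to compound 3 (beyond the scatter). Nothing available here accounts for this difference.

The compounds shown leave open whether the response depends on the size of the group on this oxygen, which an ethoxy or a longer chain would test. They also leave open whether an amine in place of the hydroxy would stay level with compound 2 or fall towards compound 3.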